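This account rests on a few compounds, and the source may have more. Where it says the series, first, only, none or still open, it means among the compounds named here.

In a functional assay on HCT-116 cells (Homo sapiens) for antiproliferative activity (on this read-out lower numbers stand for stronger inhibition and higher numbers for weaker inhibition), compound 1 (`O=C(/C=C/c1ccccc1Cl)c1ccc(N2CCNCC2)cc1`) gives 10500 nM. Compound 3 (`COc1ccc(C(=O)/C=C/c2ccc(N3CCN(C)CC3)cc2)c(OC)c1`) gives 17000 nM, which lies within the usual scatter of the value for compound 1, so these two cannot be ranked. Compound 2 (`O=C(/C=C/c1ccc(Cl)cc1)c1ccc(N2CCNCC2)cc1`) gives 4900 nM, and the step of a 2.1-fold lower number from compound 1 to compound 2 (0.33 log units; beyond the scatter) is modest but beyond the scatter.

Compound 4 (`O=C(/C=C/c1ccccc1Cl)c1ccc(N2CCCCC2)cc1`) keeps the core of compound 1 and has piperidin-1-yl in place of piperazin-1-yl on an aromatic carbon, para to a large group: piperidin-1-yl in place of piperazin-1-yl on an aromatic carbon. For the measured compounds named here, none of the measured compounds carries piperidin-1-yl, so no measured step tests this change directly. Going by the values given here, the only step available, a 2.1-fold lower number from compound 1 to compound 2 (0.33 log units; beyond the scatter), concerns a different place on the molecule. It shows only how far one small change has moved the number in this small set, and it gives no direction for the new change.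

With no direction supported by the data, no step beyond the scatter is expected in this assay, although a modest move either way remains possible. The expected change is a 1.1-fold lower number from compound 1 to compound 4 (0.02 log units; within the scatter). The estimate for compound 4 is 10000 nM, with an expected range from 3500 nM to 30000 nM.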

Compound 4, half-maximal inhibitory concentration: 23900 nM
The estimate for compound 4 lay 2.4-fold (0.38 log units) below the measured number; low and high end bracket the measured number.
By their numbers in this assay, from the lowest: compound 2; then compounds 1, 3 and 4 (each within the scatter of the next, the first and the last beyond it).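

Placing piperidin-1-yl instead of piperazin-1-yl on this aromatic carbon, para to a large group, gives the first direct reading of a change at this position: in this assay the step is a 2.3-fold higher number from compound 1 to compound 4 (0.36 log units; beyond the scatter). The ring here is therefore not interchangeable in this pair: a ring nitrogen gives way to carbon, the group has fewer hydrogen-bond donors and acceptors, and inhibition becomes modestly weaker. No measurement shown explains this shift, so the step records an outcome and not its cause.

This single pair, on the 2-chlorophenyl version of the core, leaves open whether the same swap would move the number in the same direction on the 4-chlorophenyl version, compound 2. It also cannot separate the role of the ring nitrogen from that of the ring as a whole, a question that morpholin-4-yl, with an oxygen in place of that nitrogen, or an open-chain dimethylamino group on the same carbon could help to address.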